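Furan-2-yl for 4-bromophenyl: compound 3 to compound 4

This account rests on a few compounds, and the source may have more. Where it says the series, first, only, none or still open, it means among the compounds named here.

Values in a functional assay on MKN-45 cells (Homo sapiens) for cytotoxicity, read by MTT assay, with a stated time of 72 h; on this read-out lower numbers stand for stronger inhibition and higher numbers for weaker inhibition:
- compound 1 `O=C(N/N=C/c1ccc(Br)cc1)N1CCc2ncnc(Nc3ccc(F)c(Cl)c3)c2C1`: 12100 nM
- compound 2 `N#Cc1ccc(/C=N/NC(=O)N2CCc3ncnc(Nc4ccc(F)c(Cl)c4)c3C2)cc1`: 52300 nM
- compound 3 `O=C(N/N=C/c1ccc(Br)cc1)N1CCc2ncnc(Nc3cccc(Br)c3)c2C1`: 23600 nM
- compound 4 `O=C(N/N=C/c1ccco1)N1CCc2ncnc(Nc3cccc(Br)c3)c2C1`: not yet measured

Compound 3 stands level with compound 1 within the scatter, the measured step being a 2.0-fold higher number from compound 1 to compound 3 (0.29 log units; within the scatter). That step concerns 3-bromophenyl in place of 3-chloro-4-fluorophenyl on a nitrogen on an aromatic ring, so it says little about the change at hand. The number of compound 3 is lower than that of compound 2.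

The change to compound 4 is furan-2-yl in place of 4-bromophenyl on a carbon with a double bond to nitrogen. Going by the values given here, the one measured step that replaces this bromo is a 4.3-fold higher number from compound 1 to compound 2 (0.64 log units; beyond the scatter), with cyano in place of bromo. Among the compounds with values here, compound 4 also loses the bromo, but its whole aromatic ring changes, and no furan-2-yl compound has a measured value, so the guide is thin. On the evidence of that single step, a modest move toward a higher number is expected in this assay.

The estimated step is a 2.1-fold higher number from compound 3 to compound 4 (0.33 log units; beyond the scatter). For compound 4 the expected value is 50000 nM, with an estimated range from 20000 nM to 120000 nM.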

Compound 4, half-maximal inhibitory concentration: 65700 nM
For compound 4 the middle estimate is 1.3-fold (0.12 log units) below the measured one, within the range that was stated.
By their numbers in this assay, from the lowest: compounds 1 and 3 (each within the scatter of the next); then compounds 2 and 4 (each within the scatter of the next).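

In this assay the place on the carbon with a double bond to nitrogen now has its first reading for an exchange of the whole ring rather than only the group it carries, and the result is a 2.8-fold higher number from compound 3 to compound 4 (0.44 log units; beyond the scatter) with the rest of the structure unchanged. Together with a 4.3-fold higher number from compound 1 to compound 2 (0.64 log units; beyond the scatter) this gives two steps away from a 4-bromophenyl group, each on a different group on the shared core, and both go to a higher number beyond the scatter, so neither replacement held the number level. The data at hand offer nothing that explains the size or direction of either step.

Still open, going by these compounds, is whether plain phenyl at this place would stand with compound 3 or with compound 4, which would separate the loss of the bromo from the change of ring. Also open, on these data alone, is whether the furan-2-yl step carries over to the 3-chloro-4-fluorophenyl pair, and whether a thiophen-2-yl ring or a 4-chlorophenyl group would keep the number of compound 3.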